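Two Fluorines in Place of a Trifluoromethoxy Group

The source may hold more compounds than are shown below. What is called first, only, known or untested is meant among the compounds shown, and "the series" means these compounds.

Of the compounds shown here, three that share one core have been tested in a functional assay on ME-180 cells (Homo sapiens) for cytotoxicity, read by MTT assay, with a stated time of 72 h; a lower number here means a stronger inhibitor, a higher number a weaker inhibitor. Compound 1 `COc1cccc(/C=C/C(=O)Nc2cc(C(=O)c3cc(OC)c(OC)c(OC)c3)ccc2OC)c1` gives 4300 nM, compound 2 `COc1ccc(C(=O)c2cc(OC)c(OC)c(OC)c2)cc1NC(=O)/C=C/c1ccc(C(F)(F)F)cc1` gives 800 nM, and compound 3 `COc1ccc(C(=O)c2cc(OC)c(OC)c(OC)c2)cc1NC(=O)/C=C/c1cccc(OC(F)(F)F)c1` gives 9200 nM. Compound 3 therefore stands with the highest number of the three, the weakest inhibitor here; compound 1 lies nearest to it and compound 2 furthest.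

Compound 4 `COc1ccc(C(=O)c2cc(OC)c(OC)c(OC)c2)cc1NC(=O)/C=C/c1ccc(F)c(F)c1` differs from compound 3 in one place: 3,4-difluorophenyl in place of 3-(trifluoromethoxy)phenyl on a double-bonded chain carbon bound to a double-bonded chain carbon. Going by the values given here, two measured steps bear on this change. The step of a 12-fold higher number from compound 2 to compound 3 (1.06 log units; beyond the scatter) shows a large rise when a 4-(trifluoromethyl)phenyl became a 3-(trifluoromethoxy)phenyl, and the step of a 2.1-fold higher number from compound 1 to compound 3 (0.33 log units; beyond the scatter) shows a modest rise when trifluoromethyl replaced methyl on the ring oxygen. Compound 4 gives up the trifluoromethoxy that accompanied the highest number and takes on a 3,4-difluorophenyl with no hydrogen-bond acceptor, so a lower number than compound 3 is expected, though not as low as compound 2. Compound 4 is estimated to give 2500 nM, between 700 nM and 9000 nM, an expected step of a 3.7-fold lower number from compound 3 to compound 4 (0.57 log units; beyond the scatter).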

Compound 4, half-maximal inhibitory concentration: 8900 nM
Beside the measured number, compound 4's estimate is 3.6-fold (0.55 log units) below it, and the stated range covers the measured number.
By their numbers in this assay, from the lowest: compound 2; then compound 1; then compounds 4 and 3 (each within the scatter of the next).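

In this assay, the 3,4-difluorophenyl stands level with the 3-(trifluoromethoxy)phenyl, a 1.0-fold lower number from compound 3 to compound 4 (0.01 log units; within the scatter), so losing the trifluoromethoxy group, with its oxygen and the hydrogen-bond acceptor counted there, does not by itself bring the number down. Fluorine on this ring is also no general route to a low number: an 11-fold higher number from compound 2 to compound 4 (1.05 log units; beyond the scatter) sets compound 2 well apart, and a 2.1-fold higher number from compound 1 to compound 4 (0.32 log units; beyond the scatter) puts the fluorine-bearing compound 4 on the weaker side of the methoxy-bearing compound 1, so among the fluorinated compounds only compound 2 has the lowest number. The data offer no measurement that explains why these groups differ.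

From the compounds shown here alone, it stays open whether the low number of compound 2 follows the trifluoromethyl group itself or its place on the ring. Going by these compounds, how a phenyl carrying an amine or a carboxylic acid would behave at this position also remains unknown.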